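The compounds below may be only part of what the source reports. "The series", "measured", "known", "first", "only" and "open" are said of these compounds alone.

Compound 1 `COc1cc2c(cc1CC=C(C)C)C(=O)C[C@@H](c1ccc(Oc3cccc([N+](=O)[O-])c3)cc1)O2`: 37%
Compound 2 `COc1cc2c(cc1CC=C(C)C)/C(=N/NC(N)=O)C[C@@H](c1ccc(O)cc1)O2`: 77%
Compound 3 `COc1ccc([C@@H]2C/C(=N/OCc3cn(-c4ccc(NC(=O)c5ccccc5)cc4)nn3)c3cc(CC=C(C)C)c(OC)cc3O2)cc1`: 31%

In a functional assay on A549 cells (Homo sapiens) for inhibition, read by sulforhodamine B assay, with a stated time of 48 h, tested at 50 uM (a higher number here means more inhibition of growth at the concentration tested, a lower number less inhibition of growth), compound 1 gives 37%. This number cannot be told apart from that of compound 3, at 31%, as the two lie within the usual scatter. Compound 2, at 77%, lies higher than compound 1 by a margin beyond the scatter.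

Compound 4 `COc1cc2c(cc1CC=C(C)C)C(=O)C[C@@H](c1ccc(Oc3ccc(Br)cc3)cc1)O2` keeps the core of compound 1 and carries 4-bromophenyl in place of 3-nitrophenyl on an oxygen on an aromatic ring. Among the measured compounds shown here, none of the measured compounds differ from one another in one place only, so the data offer no direct guide to the size of this change. The expectation therefore starts from compound 1 at 37%, with no step beyond the scatter foreseen in either direction. The expected change is a number 1 percentage points higher from compound 1 to compound 4 (within the scatter). For compound 4, the estimated value is 38%, with an expected range from 20% to 58%.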

Compound 4, percent growth inhibition at one concentration: 72%
For compound 4 the middle estimate is 34 percentage points below the measured one; the measured number lies above the stated range.
By their numbers in this assay, from the lowest: compounds 3 and 1 (each within the scatter of the next); then compounds 4 and 2 (each within the scatter of the next).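

In this assay the step of a number 35 percentage points higher from compound 1 to compound 4 (beyond the scatter) comes with 4-bromophenyl in place of 3-nitrophenyl on an oxygen on an aromatic ring. Among the compounds shown here, the earlier compounds differed from one another in more than one place, so this is the first sign that the group on this oxygen alone can change growth inhibition substantially on the core of compound 1. Nothing measured here accounts for the size of this step.

For the compounds shown here, the one step changes both the substituent and its number on the ring, so it cannot separate the loss of the nitro group, the gain of bromine and the move from 3 to 4. On these data alone, what 3-bromophenyl, 4-nitrophenyl, 4-chlorophenyl or an unsubstituted phenyl would give on the same oxygen remains open.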